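The source may hold more compounds than are shown below. What is called first, only, known or untested is meant among the compounds shown, and "the series" means these compounds.

Notes on the series, all read in a functional assay on HeLa cells (Homo sapiens) for antiproliferative activity, read by MTT assay, with a stated time of 48 h; on this read-out lower numbers stand for stronger inhibition and higher numbers for weaker inhibition. Compound 1 (`COc1ccc(-c2cn3cc(C4=CCN(S(=O)(=O)CCc5ccccc5)CC4)ccc3n2)cc1OC`) gives 8980 nM, compound 2 (`COc1ccc(-c2cn3cc(C4=CCN(C(=O)c5ccc(Cl)cc5)CC4)ccc3n2)cc1OC`) gives 12200 nM, and compound 3 (`COc1ccc(-c2cn3cc(C4=CCN(C(=O)c5ccccc5)CC4)ccc3n2)cc1OC`) gives 10200 nM. Compound 3 lies within the scatter of both other compounds, so the three values form one group without a ranking.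

Compound 4 (`COc1ccc(-c2cn3cc(C4=CCN(C(=O)c5cccc(C(F)(F)F)c5)CC4)ccc3n2)cc1OC`) is the next to be read, and its difference from compound 3 is trifluoromethyl in place of hydrogen on an aromatic carbon. In words, benzoyl becomes (3-(trifluoromethyl)phenyl)carbonyl, with trifluoromethyl on an aromatic carbon, meta to a large group.

The closest evidence is a 1.2-fold lower number from compound 2 to compound 3 (0.08 log units; within the scatter), where hydrogen replaces chloro on an aromatic carbon of the same ring. The larger exchanges are no more telling: a 1.1-fold higher number from compound 1 to compound 3 (0.06 log units; within the scatter) and a 1.4-fold higher number from compound 1 to compound 2 (0.13 log units; within the scatter) both stay within the scatter. Among the compounds with values here, no measured compound carries trifluoromethyl, so this evidence is indirect, and the range has to stay wide. No step beyond the scatter is expected in this assay, and no direction is favoured. The estimated change is a 1.0-fold lower number from compound 3 to compound 4 (0.01 log units; within the scatter). For compound 4 the expected value is 10000 nM, with an estimated range of 5500 nM to 19000 nM.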

Compound 4, half-maximal inhibitory concentration: 4860 nM
Compound 4: middle estimate off by 2.1-fold (0.31 log units), on the high side; the measured number lies below the stated range.
By their numbers in this assay, from the lowest: compounds 4, 1, 3 and 2 (each within the scatter of the next, the first and the last beyond it).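

In this assay, trifluoromethyl on an aromatic carbon, meta to a large group, gives the first step from hydrogen at a ring carbon that clears the scatter (a 2.1-fold lower number from compound 3 to compound 4 (0.32 log units; beyond the scatter)), whereas the exchange of chloro for hydrogen stayed within it (a 1.2-fold lower number from compound 2 to compound 3 (0.08 log units; within the scatter)). The change from 4-chlorophenyl to 3-(trifluoromethyl)phenyl on the carbonyl carbon also lies beyond the scatter (a 2.5-fold lower number from compound 2 to compound 4 (0.40 log units; beyond the scatter)), but the exchange of phenethylsulfonyl for (3-(trifluoromethyl)phenyl)carbonyl on the ring nitrogen does not (a 1.8-fold lower number from compound 1 to compound 4 (0.27 log units; within the scatter)), so compound 4 separates from compound 2 and compound 3 but not from compound 1. Nothing measured in this series bears on why the trifluoromethyl step occurs.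

Trifluoromethyl stands at only one place in the compounds shown, so it remains open whether the step belongs to the group itself or to that place on the ring. Also open, from the compounds shown here alone, is whether a nitrile, a methyl or a carboxylic acid on the same aromatic carbon would move the number as far as trifluoromethyl does.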